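Trifluoromethyl for Methyl: Cytotoxicity Expected to Stay at the Limit

The source may report more compounds than this note shows. Statements on the series, on what has been measured and on what is new or still open speak of the compounds shown alone.

Compound 1 `CCOC(=O)c1c(-c2cccc(C)c2)[nH]c2cc(OC)ccc2c1=O` was examined in an ADME assay on HepG2 cells (Homo sapiens) for cytotoxicity, read by luminescence, with a stated time of 72 h; on this read-out lower numbers stand for an effect already at smaller amounts and higher numbers for an effect only at larger amounts of compound. In this assay compound 1 gives > 21500 nM, which is a limit of the assay rather than a measured number. Compound 2 `C=Cc1cccc(-c2[nH]c3cc(OC)ccc3c(=O)c2C(=O)OCC)c1` differs from compound 1 by a vinyl in place of methyl on an aromatic carbon. In this assay compound 2 gives > 21500 nM, again a limit and not a number. The step that the two limits leave unreadable from compound 1 to compound 2 cannot be read because of the limit of > 21500 nM in this assay, at which 2 of the 2 values shown sit. So compound 1 stands at the limit of this assay, and the one neighbouring compound stands there too.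

Compound 3 `CCOC(=O)c1c(-c2cccc(C(F)(F)F)c2)[nH]c2cc(OC)ccc2c1=O` has not yet been measured. Its change from compound 1 is trifluoromethyl in place of methyl on an aromatic carbon. Within the data shown here, the single measured step is of unreadable size, so it gives no direction for this new change, and no step beyond the scatter is expected. Compound 3 is expected to give about 30000 nM in this assay, roughly between 10000 nM and 100000 nM, most probably reported once more as a limit. The expected step that the limit leaves unreadable from compound 1 to compound 3 is thus estimated to lie within the usual scatter.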

Compound 3, half-maximal effective concentration: > 21500 nM
Compound 3 was reported as a limit; the forecaster's own chance of this, stated with the estimate: 75%; the middle value is on the limit's open side.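

Among these compounds, compound 1, compound 2 and compound 3 all stop at the same limit in this assay, so no step between them can be read: the limit of > 21500 nM in this assay, at which 3 of the 3 values shown sit.

The compounds shown leave open where the real value of each one lies, and whether methyl, vinyl and trifluoromethyl differ at all on this read-out.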